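The compounds below may be only part of what the source reports. "The series", "measured", "known", "first", "only" and "open" are said of these compounds alone.

Compounds with numbers so far:

Compound 1, `CCCS(=O)(=O)Nc1cccc2c1CCCC2c1c[nH]cn1`; in an assay on isolated protein for binding affinity to Alpha-1D adrenergic receptor (Rattus norvegicus), read by radioligand binding (on this read-out lower numbers stand for stronger inhibition and higher numbers for weaker inhibition), compound 1 gives < 10000 nM, which is a limit of the assay rather than a number (the limit of < 10000 nM in this assay, at which 1 of the 3 values shown sits).
Compound 2, `O=S(=O)(Nc1cccc2c1CCCC2c1c[nH]cn1)C1CC1`; in this assay compound 2 gives 2690 nM.
Compound 3, `CCS(=O)(=O)Nc1cccc2c1CCCC2c1c[nH]cn1`; in this assay compound 3 gives 1070 nM.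

Compound 3 holds the lowest of the two numbers that are known; its nearest neighbour is compound 2, and the step of a 2.5-fold lower number from compound 2 to compound 3 (0.40 log units; beyond the scatter) separates them. The steps a step that the limit leaves unreadable from compound 1 to compound 2 and a step that the limit leaves unreadable from compound 1 to compound 3 cannot be sized, since compound 1 sits at the limit. All three measured compounds share the same core and differ only in the group on the sulfonyl sulfur.

Compound 4, `CCS(=O)(=O)Nc1cccc2c1CCCC2CNC`, has not been measured. It differs from compound 3 at another place: (methylamino)methyl in place of 1H-imidazol-4-yl on a saturated ring carbon. Within the data shown here, none of the measured steps touches this part of the molecule; each of them changes the sulfonyl substituent while the 1H-imidazol-4-yl group stays the same. The measured steps therefore give no guide to direction or size here, and the expectation for compound 4 in this assay rests on that gap rather than on any observed step. As a working estimate, compound 4 is expected to give 5000 nM, within 800 nM to 30000 nM. This estimate corresponds to an expected step of a 4.7-fold higher number from compound 3 to compound 4 (0.67 log units; beyond the scatter), with wide uncertainty in both directions.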

Compound 4, inhibition constant: < 10000 nM
Compound 4 gave a limit, no number (the forecaster's own chance of this, stated with the estimate: 40%); the middle value lies beyond the limit too.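

In this assay compound 4 gives < 10000 nM, a limit of the assay and not a number, so the step from compound 3 to compound 4 cannot be read: the limit of < 10000 nM in this assay, at which 2 of the 4 values shown sit. The compounds shown leave open how far, and in which direction, (methylamino)methyl in place of 1H-imidazol-4-yl on a saturated ring carbon moves the number in this assay.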